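A Fluorine Added to the Fused Ring of Compound 1

The source may hold more compounds than are shown below. What is called first, only, known or untested is meant among the compounds shown, and "the series" means these compounds.

Of the compounds shown here, two have been measured so far. Compound 1 `O=c1oc2ccccc2c(=O)n1-c1ccc(Cl)cc1F` gives 24400 nM in an ADME assay on RAW264.7 cells (Mus musculus) for cytotoxicity, read by MTT assay, with a stated time of 24 h; on this read-out lower numbers stand for higher toxicity in this test and higher numbers for lower toxicity in this test. Compound 2 `O=C(Nc1ccc(F)cc1F)c1cc(I)ccc1O` gives 13700 nM in this assay, which lies within the scatter of the number for compound 1, so neither stands apart from the other. Compound 3 `O=c1oc2ccc(F)cc2c(=O)n1-c1ccc(Cl)cc1F` differs from compound 1 by fluoro in place of hydrogen on an aromatic carbon. Within the data shown here, no measured pair shows what such a change does here, so the step of a 1.1-fold lower number from compound 1 to compound 3 (0.04 log units; within the scatter) is expected to stay within the scatter, in no clear direction. Compound 3 is therefore estimated at 22000 nM, with a range from 10000 nM to 50000 nM.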

Compound 3, half-maximal cytotoxic concentration: 7900 nM
Compound 3: middle estimate off by 2.8-fold (0.44 log units), on the high side; measured number outside the range, below it.
By their numbers in this assay, from the lowest: compounds 3, 2 and 1 (each within the scatter of the next, the first and the last beyond it).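

Fluoro in place of hydrogen on this aromatic carbon, meta to a fused ring and para to a fused ring, gives the first single change that can be read in this assay: a 3.1-fold lower number from compound 1 to compound 3 (0.49 log units; beyond the scatter) is a modest step toward higher toxicity in this test. So this position of the core of compound 1 is not silent, even to a change of one heavy atom. No available evidence accounts for the step. On these data alone, whether an amine or a methoxy group on the same carbon would shift the number in the same direction remains open, as does the effect of fluoro on the other carbons of that ring.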